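The source may hold more compounds than are shown below. What is called first, only, known or untested is meant among the compounds shown, and "the series" means these compounds.

Measured so far in a functional assay on MCF7 cells (Homo sapiens) for inhibition, read by sulforhodamine B assay, with a stated time of 48 h, tested at 10 uM; on this read-out lower numbers stand for less inhibition and higher numbers for more inhibition at the one concentration tested (going by the name of the read-out):

- compound 1, `O=Cc1ccc(-c2cn3ccnc3c(-c3ccc4ncn(C5CCCCC5)c4c3)n2)cc1`, gives 47.8%
- compound 2, `Clc1ccc(-c2cn3ccnc3c(-c3ccc4ncn(C5CCCCC5)c4c3)n2)cc1`, gives 21.8%
- compound 3, `Brc1ccc(-c2cn3ccnc3c(-c3ccc4ncn(C5CCCCC5)c4c3)n2)cc1`, gives 46.4%

Compound 3 stands second highest of the three numbers. Its nearest neighbour is compound 1, with a number 1.4 percentage points lower from compound 1 to compound 3 (within the scatter), so the two cannot be told apart. Compound 2 lies furthest away, with a number 24.6 percentage points higher from compound 2 to compound 3 (beyond the scatter), a modest but real gap; the same holds for a number 26 percentage points lower from compound 1 to compound 2 (beyond the scatter).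

Compound 4, `COc1ccccc1-c1cn2ccnc2c(-c2ccc3ncn(C4CCCCC4)c3c2)n1`, has not been measured. It differs from compound 3 in one place: 2-methoxyphenyl in place of 4-bromophenyl on an aromatic carbon. The 4-bromophenyl leaves and a 2-methoxyphenyl enters, bringing one hydrogen-bond acceptor.

Among the measured compounds shown here, none of the measured steps bears directly on this change: every measured step swaps one group for another on the same aromatic carbon of the phenyl, and none brings in a methoxy. The measured numbers span a modest range, so the expected step of a number 11.4 percentage points lower from compound 3 to compound 4 (beyond the scatter) is small and of uncertain direction. Compound 4 is therefore estimated at 35%, with a range from 10% to 60%.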

Compound 4, a percentage reported as inhibition, at one concentration (the size of the read-out at that concentration, not a potency): 8.4%
Beside the measured number, compound 4's estimate is 26.6 percentage points above it; measured number outside the range, below it.
By their numbers in this assay, from the lowest: compound 4; then compound 2; then compounds 3 and 1 (each within the scatter of the next).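

Among the compounds shown here, putting 2-methoxyphenyl on this aromatic carbon gives a number 38 percentage points lower from compound 3 to compound 4 (beyond the scatter) and a number 39.4 percentage points lower from compound 1 to compound 4 (beyond the scatter) in this assay, both larger than any step among the earlier compounds. Even 4-chlorophenyl, the lowest of the earlier groups, does not mark the bottom, with a number 13.4 percentage points lower from compound 2 to compound 4 (beyond the scatter) for this change, so this position can lose more inhibition than the earlier swaps showed. No measurement at hand explains this drop.

Here the group and its place on the phenyl change together, so the compounds shown leave open whether the methoxy itself or where it sits accounts for the loss. Also open, going by these compounds, is how an amine or a carboxylic acid on that phenyl would fare.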